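The compounds below may be only part of what the source reports. "The series", "measured", "known", "first", "only" and "open" are said of these compounds alone.

Measured so far in a functional assay on L02 cells (Homo sapiens) for inhibition, read by Griess assay, with stated times of 1 h and 24 h; a higher number here means a weaker inhibitor, a lower number a stronger inhibitor:

- Compound 1 `CN(C)c1nc(/C=C/c2ccccc2)nc2ccsc12`: compound 1 gives > 1000000 nM, a limit of the assay.
- Compound 2 `CCCCNc1nc(/C=C/c2ccccc2)nc2ccsc12`: compound 2 gives > 1000000 nM, also a limit of the assay.

Compound 2 therefore stands only at a limit of this assay, with no number read. Among the measured compounds shown here, the one step between measured compounds, butylamino in place of dimethylamino on an aromatic carbon, is a step that the two limits leave unreadable from compound 1 to compound 2; with the limit of > 1000000 nM in this assay, at which 2 of the 2 values shown sit, nothing about the size or direction of that step can be read.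

The next change keeps the shared core and the group on the nitrogen on an aromatic ring: 4-methoxyphenyl in place of butyl on a nitrogen on an aromatic ring, giving compound 3 `COc1ccc(Nc2nc(/C=C/c3ccccc3)nc3ccsc23)cc1`. For the measured compounds named here, the only measured step touches this same nitrogen substituent, but it is unreadable, so it supplies no expected size or direction beyond the scatter. With both measured values sitting at the limit, the most likely outcome is expected to be a further limit rather than a number.

Compound 3 is thus estimated at 1000000 nM in this assay, within 100000 nM to 3000000 nM, and the step from compound 2 to compound 3 is expected to be a number no higher from compound 2 to compound 3 (the limit leaves the size open).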

Compound 3, half-maximal inhibitory concentration: > 1000000 nM
Compound 3 was reported as a limit; the forecaster's own chance of this, stated with the estimate: 80%; the middle value lies on the limit itself.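

In this assay no step can be read from compound 2 to compound 3, as both stand only at a limit: the limit of > 1000000 nM in this assay, at which 3 of the 3 values shown sit.

The compounds shown leave open whether any group on this nitrogen, or any change to the shared core, gives a readable number in this assay at all.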